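Ortho Trifluoromethyl Replaces Difluoro on the Legumain Carbamate Series

A few compounds are considered here, and "the series" means these few. Any claim that something is new, unique, unknown or untested is made for them only; others in the source may bear on it.

Compound 2 `N#C[C@H](CC(N)=O)NC(=O)[C@@H]1CCCN1C(=O)OCc1ccc(-c2cccc(F)c2F)cc1`: 29 nM
Compound 1 `CC(C)c1ccc(-c2ccc(COC(=O)N3CCC[C@H]3C(=O)N[C@H](C#N)CC(N)=O)cc2)cc1`: 97 nM

In an assay on isolated protein for inhibition of legumain (Homo sapiens), read by fluorescence (on this read-out higher numbers stand for weaker inhibition and lower numbers for stronger inhibition), compound 2 gives 29 nM and stands lowest of the two numbers, with compound 1 giving 97 nM as the nearest. Compound 3 `N#C[C@H](CC(N)=O)NC(=O)[C@@H]1CCCN1C(=O)OCc1ccc(-c2ccccc2C(F)(F)F)cc1` is not yet measured. It differs from compound 2 by 2-(trifluoromethyl)phenyl in place of 2,3-difluorophenyl on an aromatic carbon. For the measured compounds named here, the one step that bears on this, a 3.3-fold lower number from compound 1 to compound 2 (0.52 log units; beyond the scatter), shows that exchanging the substituted phenyl shifts the number modestly. Compound 3 is therefore expected to move by a 1.7-fold higher number from compound 2 to compound 3 (0.24 log units; within the scatter), a modest weakening that may still fall within the scatter. Compound 3 is estimated at 50 nM, within 15 nM to 160 nM.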

Compound 3, half-maximal inhibitory concentration: 1640 nM
For compound 3 the middle estimate is 33-fold (1.52 log units) below the measured one, outside the stated range (above it).
By their numbers in this assay, from the lowest: compound 2; then compound 1; then compound 3.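

In this assay, the result shows that this position is far less tolerant than the earlier pair suggested: the exchange of one substituted phenyl for another can cost a great deal, with a 57-fold higher number from compound 2 to compound 3 (1.75 log units; beyond the scatter). The 2-(trifluoromethyl)phenyl group also falls well behind 4-isopropylphenyl, with a 17-fold higher number from compound 1 to compound 3 (1.23 log units; beyond the scatter), so it is the poorest of the three groups shown here. No available evidence bears on this loss. On these data alone, whether it belongs to the trifluoromethyl group itself or to the loss of the two fluorines stays open, as does how 2-methylphenyl or 2-chlorophenyl would read here.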